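Amide aryl variation in the series: the dimethoxy step

This account rests on a few compounds, and the source may have more. Where it says the series, first, only, none or still open, it means among the compounds named here.

Compounds 1, 2 and 3 share one core and differ only in the aryl of the amide. In a functional assay on MDA-MB-231 cells (Homo sapiens) for antiproliferative activity, read by CCK-8 assay, with a stated time of 72 h (on this read-out lower numbers stand for stronger inhibition and higher numbers for weaker inhibition), compound 1 `Cc1nc(C)c(/C=C/C(=O)c2ccc(NC(=O)c3ccc(F)cc3)cc2)nc1C` gives 1670 nM. Compound 2 `Cc1nc(C)c(/C=C/C(=O)c2ccc(NC(=O)c3ccccc3)cc2)nc1C` gives 1840 nM. Compound 3 `COc1ccc(C(=O)Nc2ccc(C(=O)/C=C/c3nc(C)c(C)nc3C)cc2)cc1` gives 1600 nM. Compound 2 holds the highest of the three numbers, yet its gaps to compound 1 and to compound 3 both lie within the scatter. Compound 4 `COc1cc(OC)cc(C(=O)Nc2ccc(C(=O)/C=C/c3nc(C)c(C)nc3C)cc2)c1` carries 3,5-dimethoxyphenyl in place of phenyl on a carbonyl carbon. The step that bears on it most directly is a 1.2-fold lower number from compound 2 to compound 3 (0.06 log units; within the scatter), within the scatter, as are a 1.1-fold higher number from compound 1 to compound 2 (0.04 log units; within the scatter) and a 1.0-fold lower number from compound 1 to compound 3 (0.02 log units; within the scatter). Nothing here points beyond the scatter, so the expected step is a 1.1-fold lower number from compound 2 to compound 4 (0.03 log units; within the scatter), none beyond the usual spread. Compound 4 is therefore estimated at 1700 nM, within 900 nM to 3300 nM.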

Compound 4, half-maximal inhibitory concentration: 11600 nM
Compound 4: middle estimate off by 6.8-fold (0.83 log units), on the low side; the whole stated range lies below it.
By their numbers in this assay, from the lowest: compounds 3, 1 and 2 (each within the scatter of the next); then compound 4.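

In this assay the aryl on this amide carbonyl carbon is not indifferent to change: 3,5-dimethoxyphenyl in place of phenyl gives a 6.3-fold higher number from compound 2 to compound 4 (0.80 log units; beyond the scatter). Against the other two aryls the change reads a 7.3-fold higher number from compound 3 to compound 4 (0.86 log units; beyond the scatter) and a 6.9-fold higher number from compound 1 to compound 4 (0.84 log units; beyond the scatter), while the swaps among fluoro, hydrogen and a single methoxy all stayed within the scatter. No evidence here accounts for this step.

Open, going by these compounds, is whether the step belongs to the methoxy groups themselves or to the 3,5-dimethoxyphenyl as a whole, and how a 3,5-dimethylphenyl or an aminophenyl would read on this carbonyl carbon.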